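The source may report more compounds than this note shows. Statements on the series, on what has been measured and on what is new or still open speak of the compounds shown alone.

Compounds measured so far:
compound 1 `CC#CC(CC(=O)O)c1ccc(OCc2ccc3nc(-c4ccc(CC)cc4)cn3c2)cc1` gives 496 nM in an assay on isolated protein for agonist activity at Free fatty acid receptor 1 (Homo sapiens); a lower number here means that less compound is needed, a higher number that more compound is needed for the effect
compound 2 `CC#CC(CC(=O)O)c1ccc(OCc2ccn3cc(-c4ccc(C)cc4C)nc3c2)cc1` gives 503 nM in this assay
compound 3 `CC#CC(CC(=O)O)c1ccc(OCc2ccn3cc(-c4ccc(C(C)C)cc4)nc3c2)cc1` gives 615 nM in this assay

Compound 1 stands at the lowest of the three numbers, yet its gaps to compound 2 and compound 3 both lie within the scatter, so the three are not separated. Compound 4 `CC#CC(CC(=O)O)c1ccc(OCc2ccc3nc(-c4ccccc4)cn3c2)cc1` differs from compound 1 by hydrogen in place of ethyl on an aromatic carbon. Among the measured compounds shown here, the only measured step touching the same aryl group is a 1.2-fold higher number from compound 2 to compound 3 (0.09 log units; within the scatter), where the substituents on that ring were rearranged without a change beyond the scatter. For the measured compounds named here, no measured step removes a group from that ring outright. The expectation for compound 4 is therefore a small shift toward a higher number, roughly at the edge of the scatter, a 1.5-fold higher number from compound 1 to compound 4 (0.18 log units; within the scatter). Compound 4 is estimated at 750 nM, within 350 nM to 1600 nM.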

Compound 4, half-maximal effective concentration: 979 nM
Compound 4: middle estimate off by 1.3-fold (0.12 log units), on the low side; measured number inside the range.
By their numbers in this assay, from the lowest: compounds 1, 2, 3 and 4 (each within the scatter of the next).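

Going from 4-ethylphenyl to phenyl is the first step shown that strips a group from this ring outright, and in this assay it gives a 2.0-fold higher number from compound 1 to compound 4 (0.30 log units; within the scatter). The ethyl, para to a large group, can therefore be lost without leaving the scatter, although this step reaches its outer edge. Nothing measured here offers a reason for the step.

Still open, going by these compounds, is whether an amine, a methoxy group or a fluorine at this place would move the number beyond the scatter.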